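The source may report more compounds than this note shows. Statements on the series, on what has been measured and on what is new or still open speak of the compounds shown alone.

Measured so far in a physicochemical assay for solubility, read by HPLC, at pH 7.4; on this read-out lower numbers stand for lower solubility and higher numbers for higher solubility:
compound 1, `CCCCCOCc1cc(=O)c2ccccc2[nH]1`
compound 2, `CCCCCOCc1cc(=O)c2cc([N+](=O)[O-])ccc2[nH]1`
compound 3, `CCCCCCCc1[nH]c2ccccc2c(=O)c1C(=O)OCC`

Compound 1 gives > 200000 nM in this assay; that reading is a limit of the assay, not a number. Going by the values given here, it is the only such reading among the three, namely (the limit of > 200000 nM in this assay, at which 1 of the 3 values shown sits). Compound 2 gives 15000 nM in this assay. Compound 3 gives 5000 nM in this assay, the lowest of the two actual numbers.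

Compound 2 differs from compound 1 by one change: nitro in place of hydrogen on an aromatic carbon. That single change produced an at least 13-fold lower number from compound 1 to compound 2 (1.12 log units; beyond the scatter). The cores of compound 1 and compound 3 differ in more than one place; that difference is not broken down here.

Compound 4, `CCCCCCCc1[nH]c2ccc([N+](=O)[O-])cc2c(=O)c1C(=O)OCC`, has not yet been measured. It differs from compound 3 by nitro in place of hydrogen on an aromatic carbon, the same change that turns compound 1 into compound 2. Because that change gave an at least 13-fold lower number from compound 1 to compound 2 (1.12 log units; beyond the scatter), a drop of a broadly similar kind is expected here, roughly a 10-fold lower number from compound 3 to compound 4 (1.00 log units; beyond the scatter). Compound 4 is therefore estimated at 500 nM in this assay, most likely between 150 nM and 2000 nM.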

Compound 4, solubility: 5000 nM
Beside the measured number, compound 4's estimate is 10-fold (1.00 log units) below it, and the stated range ends below it.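

In this assay, nitro in place of hydrogen on an aromatic carbon gives an at least 13-fold lower number from compound 1 to compound 2 (1.12 log units; beyond the scatter) on one core, yet no change at the digits printed from compound 3 to compound 4 (within the scatter) on the other. The large step seen on the first core therefore did not carry over to the second, which shows that this change does not shift the read-out by a fixed amount across the series, but two pairs cannot show why the outcomes part or which of them is more typical. The first step also has no exact size, since compound 1 sits at a limit of the assay and not at a number: the limit of > 200000 nM in this assay, at which 1 of the 4 values shown sits.

On these data alone, the cores of compound 1 and compound 3 differ in more than one place, so it remains open which of those differences goes with the two outcomes. Also open, as far as these compounds go, is whether an amine or a carboxylic acid in place of the nitro would behave alike on both cores.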